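Two Inactive Triazole Esters and a Bromophenyl Analogue

The source may report more compounds than this note shows. Statements on the series, on what has been measured and on what is new or still open speak of the compounds shown alone.

Compound 1 `C/C(=C\CC/C(C)=C/CC[C@@H]1[C@@]2(C)CCC(=O)C(C)(C)[C@H]2CC[C@@]1(C)O)CC/C=C(\C)C(=O)OCc1cn(-c2ccc([N+](=O)[O-])cc2)nn1`: in a functional assay on A549 cells (Homo sapiens) for antiproliferative activity, read by MTT assay, with a stated time of 48 h (a higher number here means a weaker inhibitor, a lower number a stronger inhibitor), compound 1 gives > 150000 nM, which is a limit of the assay.
Compound 2 `C/C(=C\CC/C(C)=C/CC[C@@H]1[C@@]2(C)CCC(=O)C(C)(C)[C@H]2CC[C@@]1(C)O)CC/C=C(\C)C(=O)OCc1cn(-c2ccccc2C)nn1`: in this assay compound 2 gives > 150000 nM, again only a limit.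

Compound 2 therefore stands at the edge of what this assay reports, and the step that the two limits leave unreadable from compound 1 to compound 2 cannot be read because both values sit at the limit of > 150000 nM in this assay, at which 2 of the 2 values shown sit. Compound 3 `C/C(=C\CC/C(C)=C/CC[C@@H]1[C@@]2(C)CCC(=O)C(C)(C)[C@H]2CC[C@@]1(C)O)CC/C=C(\C)C(=O)OCc1cn(-c2ccc(Br)cc2)nn1` carries the change (4-bromophenyl in place of 2-methylphenyl on an aromatic nitrogen). Among the measured compounds shown here, no measured step bears on this change, so no shift beyond the scatter is expected, which means a step of a number no higher from compound 2 to compound 3 (the limit leaves the size open) is estimated. Compound 3 is expected to give 150000 nM, within 60000 nM to 300000 nM, most likely again as a limit.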

Compound 3, half-maximal inhibitory concentration: > 150000 nM
Compound 3: a limit, no number; the forecaster's own chance of this, stated with the estimate: 80%; the middle value lies on the limit itself.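

Compound 3 gives > 150000 nM, again a limit and not a number. Among the compounds shown here, no step among compound 1, compound 2 and compound 3 can be read: the limit of > 150000 nM in this assay, at which 3 of the 3 values shown sit. On these data alone, whether exchanging these groups on the aromatic nitrogen changes activity at all remains open.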